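Lengthening the dipropylamino chain: compound 2 to compound 3

This account rests on a few compounds, and the source may have more. Where it says the series, first, only, none or still open, it means among the compounds named here.

Measured in a functional assay on PC-3 cells (Homo sapiens) for antiproliferative activity, read by WST assay, with a stated time of 3 days; a higher number here means a weaker inhibitor, a lower number a stronger inhibitor:
- compound 1 `COc1cc(-c2oc3ccccc3c(=O)c2OC(C)C)cc(OC)c1OC`: 21200 nM
- compound 2 `CCCN(CCC)CCCCOc1c(-c2cc(OC)c(OC)c(OC)c2)oc2ccccc2c1=O`: 11600 nM

With only these two compounds measured, compound 2 stands within the scatter of compound 1, so the pair cannot be ranked. The next compound is compound 3 `CCCN(CCC)CCCCCOc1c(-c2cc(OC)c(OC)c(OC)c2)oc2ccccc2c1=O`, which lengthens the chain by one carbon: (dipropylamino)methyl in place of dipropylamino on a saturated chain carbon, four bonds along the chain from an oxygen on an aromatic ring. This places (dipropylamino)methyl in place of dipropylamino on a saturated chain carbon, four bonds along the chain from an oxygen on an aromatic ring.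

Within the data shown here, only one measured step bears on this change. The step of a 1.8-fold lower number from compound 1 to compound 2 (0.26 log units; within the scatter) exchanges isopropyl for 4-(dipropylamino)butyl on an oxygen on an aromatic ring, and it stays within the scatter. Among the measured compounds shown here, no measured pair isolates chain length, so this is weak evidence. Even so, the whole side chain of compound 2 was installed with a step of only that size, so no step beyond the scatter is expected in this assay for one further chain carbon. The expected change is a 1.2-fold lower number from compound 2 to compound 3 (0.06 log units; within the scatter). Compound 3 is estimated at 10000 nM, with an expected range of 4500 nM to 22000 nM.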

Compound 3, half-maximal inhibitory concentration: 2600 nM
Compound 3: middle estimate off by 3.8-fold (0.59 log units), on the high side; the measured number lies below the stated range.
By their numbers in this assay, from the lowest: compound 3; then compounds 2 and 1 (each within the scatter of the next).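

In this assay, one further chain carbon moves the number where the whole side chain of compound 2 did not: going from 4-(dipropylamino)butyl to 5-(dipropylamino)pentyl gives a 4.5-fold lower number from compound 2 to compound 3 (0.65 log units; beyond the scatter) in this series, whereas installing the shorter chain gave only a 1.8-fold lower number from compound 1 to compound 2 (0.26 log units; within the scatter) at the same oxygen. Replacing isopropyl on that oxygen with 5-(dipropylamino)pentyl also reads beyond the scatter, at an 8.2-fold lower number from compound 1 to compound 3 (0.91 log units; beyond the scatter) on the shared core, so this position does respond in this assay and, for these two chains, the length of the chain counts. Nothing measured in this set accounts for the gain from this one carbon.

Among these compounds, with only two chain lengths carrying the amine, it remains open whether a longer chain such as 6-(dipropylamino)hexyl would lower the number further or raise it again. On these data alone, it is also open how much depends on the amine end itself, which a diethylamino or piperidine group at the end of the five-carbon chain, or a chain of the same length ending in a hydroxyl group, would separate from chain length.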